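Methoxy position swap on the biaryl tail of compound 1

A few compounds are considered here, and "the series" means these few. Any claim that something is new, unique, unknown or untested is made for them only; others in the source may bear on it.

Three compounds of this series have a number in a physicochemical assay for lipophilicity, read by HPLC, at pH 7.5; on this read-out higher numbers stand for higher lipophilicity and lower numbers for lower lipophilicity. Compound 1 `CC[C@@H](Nc1c(C#N)c(-c2ccc(-c3ccc(OC)cc3)cc2)nc2cnccc12)C(N)=O` gives 2.7, the second highest of the three. Compound 2 `CCOc1ccccc1-c1ccc(-c2nc3cnccc3c(N)c2C#N)cc1` gives 3, within the scatter of compound 1. Compound 3 `CCOc1ccccc1-c1ccc(-c2nc3cnccc3c(N[C@H](CC)C(=O)NS(C)(=O)=O)c2C#N)cc1` gives 2.2, beyond the scatter below compound 1. Going by the values given here, the one step between measured neighbours, a number 0.80 log units lower from compound 2 to compound 3 (beyond the scatter), concerns a different change and does not bear on the present one. Compound 4 `CC[C@@H](Nc1c(C#N)c(-c2ccc(-c3cccc(OC)c3)cc2)nc2cnccc12)C(N)=O` differs from compound 1 by 3-methoxyphenyl in place of 4-methoxyphenyl on an aromatic carbon. Among the compounds with values here, no measured pair shows what moving the methoxy group on the terminal ring does in this assay, so no step beyond the scatter is expected; the step of no change at the digits printed from compound 1 to compound 4 (within the scatter) is expected to stay within it. Compound 4 is therefore estimated at 2.7, ranging from 2.4 to 3.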

Compound 4, distribution coefficient: 2.7
Estimate against measurement, compound 4: no gap at the digits printed; low and high end bracket the measured number.
By their numbers in this assay, from the lowest: compound 3; then compounds 1, 4 and 2 (each within the scatter of the next).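

In this assay, going by these compounds alone, the first pair at this position gives no change at the digits printed from compound 1 to compound 4 (within the scatter) and so puts 3-methoxyphenyl and 4-methoxyphenyl level on this read-out. That holds for this one pair, on the core and side chain of compound 1 only. Nothing measured on hand accounts for the match. Going by these compounds, what an amine or a carboxylic acid in place of the methoxy group on this ring would do in this assay stays open. So does a longer chain such as propoxy there, and whether the match carries over to other side chains.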